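The source may hold more compounds than are shown below. What is called first, only, known or untested is meant among the compounds shown, and "the series" means these compounds.

Compound 1, with the structure `CC1(C)CCC[C@]2(C)[C@@H](/C=C/C3=CCOC3=O)C(C=O)=CC(=O)[C@@H]12`, is one of three compounds from this study that have been tested in a functional assay on A549 cells (Homo sapiens) for inhibition, read by sulforhodamine B assay; a higher number here means that more compound is tolerated, a lower number that less compound is tolerated. In this assay compound 1 gives 45900 nM, the highest of the three numbers. Compound 3, with the structure `CC(C)(O)C1CC[C@@]2(C)CCC[C@@](C)(O)[C@@H]2C1`, gives 27400 nM, a number that lies within the scatter of the value for compound 1, so the two cannot be ordered. Compound 2, with the structure `C=C1CC[C@H]2C(C)(C)CCC[C@]2(C)[C@H]1CCC1=CC(O)OC1=O`, gives 9500 nM, which stands beyond the scatter below compound 1.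

Compound 4, with the structure `CC1=CC(=O)[C@H]2C(C)(C)CCC[C@]2(C)[C@H]1/C=C/C1=CCOC1=O`, has not yet been measured. It differs from compound 1 in a single change: methyl in place of formyl on a double-bonded ring carbon. Going by the values given here, no pair of measured compounds shows a change of this kind, so there is no measured step to lean on. The expectation for this assay rests only on the value of compound 1, 45900 nM, and on the small size of the change. The step from compound 1 to compound 4 is expected to be at most a modest rise, very possibly none beyond the scatter, giving a 1.3-fold higher number from compound 1 to compound 4 (0.12 log units; within the scatter). Compound 4 is therefore estimated to give 60000 nM in this assay, with a range from 20000 nM to 180000 nM.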

Compound 4, concentration lethal to 50% of the cells: 39600 nM
Estimate against measurement, compound 4: 1.5-fold (0.18 log units) above; measured number inside the range.
By their numbers in this assay, from the lowest: compound 2; then compounds 3, 4 and 1 (each within the scatter of the next).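

In this assay the change of formyl to methyl on the double-bonded ring carbon gives a 1.2-fold lower number from compound 1 to compound 4 (0.06 log units; within the scatter) and stays within the scatter, so compound 1 and compound 4 cannot be ordered. Going by these compounds alone, this is the first pair that differs in one place, and it shows that, on the core of compound 1, this ring carbon can carry either group with no readable change in this read-out, even though the formyl brings a double bond and a hydrogen-bond acceptor that the methyl lacks. Nothing available here bears on what lies behind this result.

The compounds shown hold only formyl and methyl at this position, so it remains open whether a carboxylic acid, an amine or a longer chain would also leave the number where it stands. As far as these compounds go, it also remains open whether the same change would read alike on another core, since this is a single pair in a single assay, and compound 2 and compound 3 each differ from compound 1 in more than one place.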